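The compounds below may be only part of what the source reports. "The series", "measured", "known", "first", "only" and "open" are said of these compounds alone.

Of the compounds shown here, three have been measured in a functional assay on CHO cells for agonist activity at prostaglandin E2 receptor EP3 subtype (Homo sapiens), read by fluorescence and calcium flux; a lower number here means that less compound is needed, a higher number that more compound is needed for the effect. Compound 1 `O=C(O)CCC/C=C\C[C@@H]1[C@@H](/C=C/[C@@H](O)CCc2ccccc2)[C@H](O)C[C@@H]1O` gives 8600 nM. Compound 2 `O=C(O)CCC/C=C\C[C@H]1C(=O)C[C@@H](O)[C@@H]1/C=C/[C@@H](O)COc1ccccc1` gives 0.89 nM. Compound 3 `O=C(O)CCCC1=CC[C@@H]2[C@@H](/C=C/[C@@H](O)COc3ccccc3)[C@H](O)C[C@@H]2OC1` gives 4700 nM. Among these numbers compound 3 has the second highest; the gap to compound 1 lies within the usual scatter of such measurements, so the two cannot be told apart, while the gap to compound 2 is very large and lies far beyond the scatter.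

Compound 4 `O=C(O)CCCCCC1=CC[C@@H]2[C@@H](/C=C/[C@@H](O)COc3ccccc3)[C@H](O)C[C@@H]2OC1` has not yet been measured. It differs from compound 3 in one place: 2-carboxyethyl in place of carboxy on a saturated chain carbon, three bonds along the chain from a double-bonded ring carbon. Among the compounds with values here, no measured pair shows this kind of chain lengthening on the shared core, so no step size can be read off. The acid-bearing chain of compound 3 already matches the length found in compound 2, which gives the lowest number; adding length to it is therefore expected to give no gain, and more likely a somewhat higher number. The step from compound 3 to compound 4 is estimated as a 1.9-fold higher number from compound 3 to compound 4 (0.28 log units; within the scatter). In this assay compound 4 is expected to give about 9000 nM, with a plausible range from 2500 nM to 30000 nM.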

Compound 4, half-maximal effective concentration: 6400 nM
The estimate for compound 4 lay 1.4-fold (0.15 log units) above the measured number, and the stated range covers the measured number.
By their numbers in this assay, from the lowest: compound 2; then compounds 3, 4 and 1 (each within the scatter of the next).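

In this assay, putting 2-carboxyethyl in place of carboxy on a saturated chain carbon, three bonds along the chain from a double-bonded ring carbon, gives a 1.4-fold higher number from compound 3 to compound 4 (0.13 log units; within the scatter). Within the data shown here, this is the first direct reading of this change on the shared core, and it shows that this added chain length leaves the two compounds indistinguishable, so at this position the acid can sit further out without a detectable shift in the number. Nothing available here bears on why the number holds steady.

Still open, from the compounds shown here alone, is whether 4-carboxybutyl, the length in between, or a chain ending in an amide or an alcohol rather than a carboxylic acid would read the same. Also open, going by these compounds, is whether this lengthening would be as small a step on the core of compound 2, which gives 0.89 nM.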